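This account rests on a few compounds, and the source may have more. Where it says the series, first, only, none or still open, it means among the compounds named here.

Compound 1 `COC(=O)c1c(N)sc(-c2ccccc2)c1C`: 4100 nM
Compound 2 `CCCOC(=O)c1c(N)sc(-c2ccccc2)c1C`: 2400 nM

In an in vitro functional assay on HEK293 cells for antagonist activity at metabotropic glutamate receptor 6 (Homo sapiens), read by reporter gene assay, luminescence and calcium flux, tested at 10 uM (on this read-out higher numbers stand for weaker inhibition and lower numbers for stronger inhibition), compound 2 gives 2400 nM, the lowest of the two numbers, while compound 1 gives 4100 nM; the gap is a 1.7-fold lower number from compound 1 to compound 2 (0.23 log units; within the scatter). Compound 3 `Cc1c(-c2ccccc2)sc(N)c1C(=O)c1ccccc1` differs from compound 2 by phenyl in place of propoxy on a carbonyl carbon. Among the compounds with values here, the single measured step, a 1.7-fold lower number from compound 1 to compound 2 (0.23 log units; within the scatter), concerns only the chain on the ester oxygen, not replacement of the propoxy by a ring on the carbonyl carbon, so no measured step bears directly on this change. With nothing pointing either way, the expected step is a 1.0-fold higher number from compound 2 to compound 3 (0.02 log units; within the scatter), not beyond the scatter. Compound 3 is therefore estimated at 2500 nM, in a range from 700 nM to 9000 nM.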

Compound 3, half-maximal inhibitory concentration: 10600 nM
Beside the measured number, compound 3's estimate is 4.2-fold (0.63 log units) below it; measured number above the stated range.
By their numbers in this assay, from the lowest: compounds 2 and 1 (each within the scatter of the next); then compound 3.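

In this assay, the change of ester chain stayed within the scatter, but replacing the ester's oxygen-linked chain with a ring does not: phenyl in place of propoxy gives a 4.4-fold higher number from compound 2 to compound 3 (0.65 log units; beyond the scatter), and phenyl in place of methoxy gives a 2.6-fold higher number from compound 1 to compound 3 (0.41 log units; beyond the scatter). On this carbonyl carbon, then, phenyl gives weaker inhibition than either ester group shown. No evidence at hand explains this shift. Still open, as far as these compounds go, is whether the ring itself or the missing ester oxygen accounts for the shift, and how an amine or a benzyloxy group on the same carbonyl carbon would compare.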